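Compound 2 to compound 3: methoxy to hydroxy

This account rests on a few compounds, and the source may have more. Where it says the series, first, only, none or still open, it means among the compounds named here.

In a functional assay on HeLa cells (Homo sapiens) for cytotoxicity, read by MTT assay, with a stated time of 72 h (a lower number here means a stronger inhibitor, a higher number a weaker inhibitor), compound 1 (`COc1cc2cc(Cc3ccc(O)cc3)c(=O)oc2cc1O`) gives 69500 nM as a measured number. Compound 2 (`COc1ccc(C(=O)CCc2c(OC)cc(O)cc2OC)cc1`) gives > 100000 nM and this is a limit of the assay, not a number. Compound 2 thus stands at the limit of > 100000 nM in this assay, at which 1 of the 2 values shown sits, and offers no exact starting value.

Compound 3 (`COc1cc(O)cc(OC)c1CCC(=O)c1ccc(O)cc1`) differs from compound 2 by hydrogen in place of methyl on an oxygen on an aromatic ring, read one bond further out as methoxy to hydroxy. Within the data shown here, no measured pair shows this change. Among the measured compounds shown here, the only number to lean on is compound 1 at 69500 nM in the same assay. In this assay a small step towards stronger inhibition is expected, possibly none beyond the scatter. The estimate is an at least 1.2-fold lower number from compound 2 to compound 3 (0.09 log units; that floor lies within the scatter) and another reading at the limit remains possible. Compound 3 is estimated at 80000 nM within an expected range of 35000 nM to 150000 nM for this read-out.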

Compound 3, half-maximal inhibitory concentration: 49000 nM
For compound 3 the middle estimate is 1.6-fold (0.21 log units) above the measured one; the range from low to high includes it.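

In this assay, methoxy to hydroxy on an oxygen on an aromatic ring gives the series its first readable step: an at least 2.0-fold lower number from compound 2 to compound 3 (0.30 log units; that floor lies within the scatter). Compound 2 stands at a limit of the assay, not at a number: the limit of > 100000 nM in this assay, at which 1 of the 3 values shown sits. With hydroxy in this place, compound 3 gives a measured number, yet the step remains a floor and not a full size, and this single pair shows no pattern beyond these two compounds.

From the compounds shown here alone, whether the same change at the remaining methoxy groups of compound 3 would give a similar step stays open. Also open, going by these compounds, is how this assay would respond to a larger group on this oxygen, such as ethoxy, or to an amine in place of the hydroxy of compound 3.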